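Methyl for fluoro on the phenyl ring of compound 3

The source may report more compounds than this note shows. Statements on the series, on what has been measured and on what is new or still open speak of the compounds shown alone.

Measured so far:
compound 1, `Fc1ccc(-c2cn3nc(Cc4ccc(Cl)cc4)sc3n2)cc1`: > 250000 nM
compound 2, `Fc1ccc(-c2nc3sc(Cc4ccc(Cl)cc4)nn3c2Br)cc1`: > 250000 nM
compound 3, `N#CSc1c(-c2ccc(F)cc2)nc2sc(Cc3ccc(Cl)cc3)nn12`: 23000 nM

In a functional assay on L1210 cells (Mus musculus) for cytotoxicity, with a stated time of 48 h (a higher number here means a weaker inhibitor, a lower number a stronger inhibitor), compound 1 gives > 250000 nM, which is a limit of the assay rather than a number. In this assay compound 2 likewise gives > 250000 nM, again a limit. Among the compounds with values here, compound 3 is the only one with a real number, 23000 nM in this assay. The steps of an at least 10-fold lower number from compound 1 to compound 3 (1.03 log units; beyond the scatter) and an at least 10-fold lower number from compound 2 to compound 3 (1.03 log units; beyond the scatter) are both large, while a step that the two limits leave unreadable from compound 1 to compound 2 cannot be read because both values sit at the same limit, (the limit of > 250000 nM in this assay, at which 2 of the 3 values shown sit).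

Compound 4, `Cc1ccc(-c2nc3sc(Cc4ccc(Cl)cc4)nn3c2SC#N)cc1`, differs from compound 3 by methyl in place of fluoro on an aromatic carbon. Within the data shown here, none of the measured steps touches this place: all three alter the substituent on the core, not the phenyl ring. Among the measured compounds shown here, there is therefore no measured step from which to read a direction, and the expectation is a step of no more than the usual scatter. Compound 4 is expected to give 23000 nM in this assay, within a range of 7000 nM to 80000 nM, meaning an expected step of no change at the digits printed from compound 3 to compound 4 (within the scatter).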

Compound 4, half-maximal inhibitory concentration: 32000 nM
For compound 4 the middle estimate is 1.4-fold (0.14 log units) below the measured one; measured number inside the range.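

In this assay the move from 4-fluorophenyl to 4-methylphenyl gives a 1.4-fold higher number from compound 3 to compound 4 (0.14 log units; within the scatter), so the two compounds cannot be told apart. Within the data shown here, the earlier steps all altered the substituent on the core, which makes this the only step that speaks to the phenyl ring, and at this place the one group stands in for the other with no readable cost. With either group on the ring a real number remains wherever cyanosulfanyl is present, whereas compound 1 and compound 2, which lack it, sit at a limit: the limit of > 250000 nM in this assay, at which 2 of the 4 values shown sit.

Fluoro and methyl are both small, so it remains open whether an amine, a carboxylic acid or a longer chain at this place would be tolerated as well. The compounds shown also do not say why cyanosulfanyl on the core goes with a measurable number.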